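A few compounds are considered here, and "the series" means these few. Any claim that something is new, unique, unknown or untested is made for them only; others in the source may bear on it.

Within the data shown here, in a functional assay on HCT-116 cells (Homo sapiens) for inhibition, read by MTT assay, with a stated time of 96 h (on this read-out higher numbers stand for weaker inhibition of growth and lower numbers for stronger inhibition of growth), compound 1 `CC(C)C(=O)SCCCCCCNC(=O)c1cc(-c2ccncc2)n[nH]1` gives 22700 nM, the only actual number so far. Compound 2 `O=C(NCCCCCCS)c1cc(-c2ccc(-c3ccccc3)cc2)n[nH]1` reads > 50000 nM, and this entry is a limit of the assay, not a number. The next compound to be measured is compound 3 `CCCC(=O)SCCCCCCNC(=O)c1cc(-c2ccncc2)n[nH]1`, which has the same atoms as compound 1, joined differently: propyl in place of isopropyl on a carbonyl carbon. In words, this is propyl in place of isopropyl on a carbonyl carbon. The expectation rests on compound 1 alone, at 22700 nM. Among the measured compounds shown here, no measured step bears on this change, and a shift beyond the usual scatter in this assay is not expected in either direction. The expected size of the change is a 1.3-fold lower number from compound 1 to compound 3 (0.10 log units; within the scatter). The estimate for compound 3 is 18000 nM, with an expected range of 7000 nM to 45000 nM.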

Compound 3, concentration for 50% growth inhibition: 23500 nM
Beside the measured number, compound 3's estimate is 1.3-fold (0.12 log units) below it, and the stated range covers the measured number.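

In this assay the exchange of isopropyl for propyl on a carbonyl carbon whose other neighbour is sulfur is a 1.0-fold higher number from compound 1 to compound 3 (0.02 log units; within the scatter) and gives the series its first readable step between two measured compounds. At this position, the two groups cannot be told apart in this read-out, so moving from the branched to the straight arrangement of the same atoms carries no measurable consequence here. Among these compounds, nothing measured so far bears on why the step is this small.

Going by these compounds, whether a longer chain such as hexyl, a ring such as phenyl, or an amine on this carbonyl carbon would shift the number beyond the scatter remains open. The pair also says nothing about any other part of the core of compound 1 .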